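The compounds below may be only part of what the source reports. "The series", "measured", "known", "first", "only" and "open" are said of these compounds alone.

Measured in a functional assay on NIH3T3 cells (Mus musculus) for inhibition, read by MTT assay, with a stated time of 72 h; on this read-out lower numbers stand for stronger inhibition and higher numbers for weaker inhibition:
- compound 1 `C=C1CC[C@H]2[C@@](C)(CC[C@@H](OC(C)=O)[C@@]2(C)C(=O)OC)[C@@H]1CCC1=CCOC1=O`: 80600 nM
- compound 2 `C=C1CC[C@H]2[C@@](C)(CC[C@@H](OC(C)=O)[C@@]2(C)C(=O)OCc2ccccc2)[C@@H]1CCC1=CCOC1=O`: 12900 nM

Compound 2 holds the lower of the two numbers, at 12900 nM. Next is compound 3 `C=C1CC[C@H]2[C@@](C)(CC[C@@H](OC(C)=O)[C@@]2(C)C(=O)OCc2ccccn2)[C@@H]1CCC1=CCOC1=O`, with the change pyridin-2-yl in place of phenyl on a saturated chain carbon bound to an oxygen next to a carbonyl group.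

Going by the values given here, only one measured step bears on this place, the modest 6.2-fold lower number from compound 1 to compound 2 (0.80 log units; beyond the scatter), which brought in the phenyl. Among the compounds with values here, no measured step exchanges the aromatic ring itself, so the size of this change is not known directly. An aromatic ring stays in place, so a smaller step than that one is expected in this assay, tilted slightly towards a higher number. The expected step is a 1.4-fold higher number from compound 2 to compound 3 (0.14 log units; within the scatter). For compound 3 the estimated value is 18000 nM, with an expected range of 7000 nM to 45000 nM.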

Compound 3, half-maximal inhibitory concentration: 55500 nM
Estimate against measurement, compound 3: 3.1-fold (0.49 log units) below, outside the stated range (above it).
By their numbers in this assay, from the lowest: compound 2; then compounds 3 and 1 (each within the scatter of the next).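

In this assay the aromatic ring at this place is not interchangeable: pyridin-2-yl in place of phenyl, with the same count of heavy atoms, gives a 4.3-fold higher number from compound 2 to compound 3 (0.63 log units; beyond the scatter) and shows that an aromatic ring alone does not keep the reading of compound 2. Against hydrogen at the same place, pyridin-2-yl gives a 1.5-fold lower number from compound 1 to compound 3 (0.16 log units; within the scatter) and so cannot be told apart from compound 1 on this read-out. No measured data bear on why the two aromatic rings differ.

Still open, from the compounds shown here alone, is whether other rings at this place, such as thienyl or pyrimidinyl, read like phenyl or like pyridin-2-yl. Also open, going by these compounds, is how a longer chain between the oxygen and the phenyl, or a methoxy group on the phenyl, would read.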